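Aryl for pentyl on the ring-nitrogen oxygen of a lactam

The compounds below may be only part of what the source reports. "The series", "measured", "known", "first", "only" and "open" are said of these compounds alone.

Compound 1 `CCCON1C(=O)[C@@H](NC(=O)OCCCCC2CCCCC2)[C@@H]1C`: 133 nM
Compound 2 `CCCCCON1C(=O)[C@@H](NC(=O)OCCCCC2CCCCC2)[C@@H]1C`: 387 nM

Compounds 1 and 2 share a core and differ only in the chain on the oxygen attached to the ring nitrogen. In an assay on HEK293 cells for inhibition of N-acylethanolamine-hydrolyzing acid amidase (Homo sapiens), read by fluorescence, with stated times of 10 min and 50 min (a higher number here means a weaker inhibitor, a lower number a stronger inhibitor), compound 1 gives 133 nM, and compound 2 gives 387 nM. For the measured compounds named here, the one measured step is a 2.9-fold higher number from compound 1 to compound 2 (0.46 log units; beyond the scatter). Compound 2 therefore stands with the highest number of the two, a modest distance from compound 1.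

Compound 3 `COC(=O)c1ccc(ON2C(=O)[C@@H](NC(=O)OCCCCC3CCCCC3)[C@@H]2C)cc1` has not yet been measured. It differs from compound 2 in this way: 4-(methoxycarbonyl)phenyl in place of pentyl on an oxygen.

Going by the values given here, no measured step bears directly on this change: the only step in hand lengthens an alkyl chain by ethyl, whereas here an aryl ester group replaces the whole pentyl. The data thus give no direction, and the spread of the estimate is wide. The step of a 1.5-fold lower number from compound 2 to compound 3 (0.19 log units; within the scatter) is expected to lie within the scatter. Compound 3 is estimated to give about 250 nM, with a range from 50 nM to 1250 nM.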

Compound 3, half-maximal inhibitory concentration: 17 nM
Estimate against measurement, compound 3: 15-fold (1.17 log units) above, outside the stated range (below it).
By their numbers in this assay, from the lowest: compound 3; then compound 1; then compound 2.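

In this assay, the oxygen on the ring nitrogen turns out to tolerate far more than a short alkyl chain: 4-(methoxycarbonyl)phenyl in place of pentyl gives a 23-fold lower number from compound 2 to compound 3 (1.36 log units; beyond the scatter), and in place of propyl it gives a 7.8-fold lower number from compound 1 to compound 3 (0.89 log units; beyond the scatter). The earlier pair showed only that pentyl carries a higher number than propyl, whereas compound 3 shows that a change at this same oxygen can lower the number well past both alkyl compounds, making compound 3 the strongest inhibitor of the three. Nothing in the data shown accounts for this drop in the number.

The compounds shown leave open whether the aromatic ring, the methoxycarbonyl group or the two together produce the drop, since the entering group differs from both alkyl chains in all these respects at once. From the compounds shown here alone, a plain phenyl on the same oxygen, or a carboxylic acid in place of the methyl ester, would separate these parts, and it also remains open whether the gain would hold on a core with a different carbamate chain.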